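Two Esters on a Shared Core, and a Third to Come

The source may report more compounds than this note shows. Statements on the series, on what has been measured and on what is new or still open speak of the compounds shown alone.

Compound 1 `CC1=CC[C@H]2[C@H](CC[C@]2(C)O)C(C)(C)[C@@H]1CC[C@H]1[C@]2(C)CC[C@H](OC(=O)CCC(=O)O)C(C)(C)O[C@H]2CC[C@@]1(C)O` carries a (2-carboxyethyl)carbonyl ester on its core. In a functional assay on MDA-MB-231 cells (Homo sapiens) for antiproliferative activity, read by MTT assay, with a stated time of 72 h (a lower number here means a stronger inhibitor, a higher number a weaker inhibitor), compound 1 gives 27900 nM, the highest of the two numbers recorded so far. Compound 2 `CC1=CC[C@H]2[C@H](CC[C@]2(C)O)C(C)(C)[C@@H]1CC[C@H]1[C@]2(C)CC/C(=N/OC(=O)c3ccccc3)C(C)(C)O[C@H]2CC[C@@]1(C)O` replaces that ester with an oxime bearing a benzoyl group; in this assay compound 2 gives 27400 nM, which sits within the scatter of the number for compound 1, so the two cannot be told apart on these data.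

Compound 3 `CC1=CC[C@H]2[C@H](CC[C@]2(C)O)C(C)(C)[C@@H]1CC[C@H]1[C@]2(C)CC[C@H](OC(=O)c3ccc(Cl)c(Cl)c3)C(C)(C)O[C@H]2CC[C@@]1(C)O` is the next member. It differs from compound 1 at a single place: 3,4-dichlorophenyl in place of 2-carboxyethyl on a carbonyl carbon. Among the compounds with values here, no step between two measured compounds covers such a change, so the expectation rests on the two numbers alone. Since compound 1 and compound 2 give much the same reading with very different groups at this end of the core, the step is expected to be modest, toward a lower number if anything, and it may fall within the scatter: the step of a 1.9-fold lower number from compound 1 to compound 3 (0.27 log units; within the scatter) is the estimate. For compound 3 the expected value in this assay is 15000 nM, with a range from 5000 nM to 45000 nM.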

Compound 3, half-maximal inhibitory concentration: 8100 nM
For compound 3 the middle estimate is 1.9-fold (0.27 log units) above the measured one, within the range that was stated.
By their numbers in this assay, from the lowest: compound 3; then compounds 2 and 1 (each within the scatter of the next).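

In this assay, 3,4-dichlorophenyl in place of 2-carboxyethyl on a carbonyl carbon gives a 3.4-fold lower number from compound 1 to compound 3 (0.54 log units; beyond the scatter). Within the data shown here, this is the first step on the shared core that changes one place only, and it shows that the reading does respond to the group this carbonyl carbon carries. The exchange removes a chain ending in a carboxylic acid and brings in an aromatic ring with chlorine on it, and nothing measured here speaks to the reason for the step.

With these compounds, the part played by the ring cannot be separated from that of the chlorines, so a plain phenyl, a single chlorine on the ring or a methoxy group in their place would each bear on that question, as would a chain ending in an amine. On these data alone, it also remains open whether 3,4-dichlorophenyl would give a similar step on the oxime of compound 2, where it would take the place of the phenyl of the benzoyl group.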